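The source may hold more compounds than are shown below. What is called first, only, known or untested is meant among the compounds shown, and "the series" means these compounds.

Cytotoxicity across the series has been followed in an ADME assay on Vero cells (Chlorocebus sabaeus) for cytotoxicity, read by MTT assay, with a stated time of 72 h; a lower number here means that less compound is tolerated, a higher number that more compound is tolerated. Compound 1 `C=CCN(CC=C)C(=S)N/N=C\c1ccc([N+](=O)[O-])cc1` gives only a limit there, < 206000 nM (the limit of < 206000 nM in this assay, at which 1 of the 3 values shown sits). Within the data shown here, compound 2 `C/C(=N/NC(=S)N(Cc1ccccc1)Cc1ccccc1)c1ccccc1` gives 167000 nM and compound 3 `Oc1ccccc1/C=N\NC(=S)N(Cc1ccccc1)Cc1ccccc1` gives 166000 nM, the two numbers sitting within the scatter of each other; the step of a 1.0-fold lower number from compound 2 to compound 3 (0.00 log units; within the scatter) is the only measured step, and it concerns the groups on the amide-type nitrogen, not the aryl on the hydrazone side. Compound 4 `O=[N+]([O-])c1ccccc1/C=N\NC(=S)N(Cc1ccccc1)Cc1ccccc1` differs from compound 3 by nitro in place of hydroxy on an aromatic carbon. Among the measured compounds shown here, no measured step touches this position, and compound 1, which carries nitro, shows only a limit. For compound 4 the estimate in this assay is therefore 166000 nM, from 80000 nM to 340000 nM. That expected step is no change at the digits printed from compound 3 to compound 4 (within the scatter), nothing beyond the scatter.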

Compound 4, half-maximal cytotoxic concentration: < 155000 nM
Compound 4: only a limit was reported; the forecaster's own chance of this, stated with the estimate: 30%; middle value at least 1.0-fold (0.02 log units) from the limit.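

In this assay, among these compounds, the change from 2-hydroxyphenyl to 2-nitrophenyl now has a first reading at this position: an at least 1.0-fold lower number from compound 3 to compound 4 (0.02 log units; that floor lies within the scatter). Compound 4 gives a limit, not a number, so that step is only a floor: the limit of < 155000 nM in this assay, at which 1 of the 4 values shown sits. Compound 1, the other nitro compound shown, also gives only a limit: the limit of < 206000 nM in this assay, at which 1 of the 4 values shown sits.

From the compounds shown here alone, whether the full step from hydroxy to nitro lies beyond the scatter remains open. Also open, going by these compounds, is how an amine or a carboxylic acid on the same aromatic carbon would read.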